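This account rests on a few compounds, and the source may have more. Where it says the series, first, only, none or still open, it means among the compounds named here.

Measured compounds in an ADME assay on Vero cells (Chlorocebus sabaeus) for cytotoxicity, read by MTT assay, with a stated time of 48 h; on this read-out higher numbers stand for weaker inhibition and lower numbers for stronger inhibition:

- compound 1, `CC(C)S(=O)(=O)OC1CCC(CN2CCN(c3cc(=O)c4cc(C(F)(F)F)cc([N+](=O)[O-])c4s3)CC2)CC1`, gives > 64 ug/mL.
- compound 2, `COc1ccc(C(=O)OC2CCC(CN3CCN(c4cc(=O)c5cc(C(F)(F)F)cc([N+](=O)[O-])c5s4)CC3)CC2)cc1`, gives > 64 ug/mL.
- compound 3, `O=C(OC1CCC(CN2CCN(c3cc(=O)c4cc(C(F)(F)F)cc([N+](=O)[O-])c4s3)CC2)CC1)c1cccc(C(F)(F)F)c1`, gives > 64 ug/mL.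

Every one of these values is a limit of the assay and not a number. Compound 3 therefore stands where the other two stand, at the limit (the limit of > 64 ug/mL in this assay, at which 3 of the 3 values shown sit), and nothing separates the three on the read-out. The steps among them cannot be read: a step that the two limits leave unreadable from compound 1 to compound 2, a step that the two limits leave unreadable from compound 1 to compound 3 and a step that the two limits leave unreadable from compound 2 to compound 3 are each unreadable because the limit of > 64 ug/mL in this assay, at which 3 of the 3 values shown sit, is where both ends of every pair sit.

Compound 4, `COc1cccc(C(=O)OC2CCC(CN3CCN(c4cc(=O)c5cc(C(F)(F)F)cc([N+](=O)[O-])c5s4)CC3)CC2)c1`, is the next member. Its difference from compound 3 is methoxy in place of trifluoromethyl on an aromatic carbon. Among the measured compounds shown here, no measured step bears directly on this exchange at that position; the only step that touches a methoxy or a trifluoromethyl on the benzoyl ring is the one from compound 2 to compound 3, and it is unreadable. Since every measured ester and sulfonate of this core sits at the limit, the expectation is that compound 4 does the same, with a step that the limit leaves unreadable from compound 3 to compound 4 expected as the step, i.e. none readable. Compound 4 is estimated at 80 ug/mL, with a range from 40 ug/mL to 200 ug/mL, most likely reported again only as a limit.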

Compound 4, half-maximal inhibitory concentration: > 64 ug/mL
Compound 4 ended at the assay's limit (the forecaster's own chance of this, stated with the estimate: 85%); the middle value lies beyond the limit too.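

No new step can be read for compound 4 against compound 1, compound 2 or compound 3 in this assay, because all four values are limits of the assay and not numbers: the limit of > 64 ug/mL in this assay, at which 4 of the 4 values shown sit.

The compounds shown leave open how far each of the four lies past that limit, and whether any of the exchanged groups changes the read-out at all.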